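Swapping the chloro of compound 2 for an amino group

A few compounds are considered here, and "the series" means these few. Any claim that something is new, unique, unknown or untested is made for them only; others in the source may bear on it.

Compound 1 `Nc1nn(C(=O)Nc2ccc(Cc3ccccc3)cc2)c2ccccc12` gives 530 nM in a functional assay on SF-295 cells (Homo sapiens) for antiproliferative activity, read by sulforhodamine B assay, with a stated time of 48 h; on this read-out lower numbers stand for stronger inhibition of growth and higher numbers for weaker inhibition of growth. Compound 2 `Nc1nn(C(=O)Nc2ccc(Cc3ccccc3)cc2)c2ccc(Cl)cc12` gives 51.5 nM in this assay.

Compound 2 stands lowest of the two numbers; its nearest neighbour is compound 1, and the step of a 10-fold lower number from compound 1 to compound 2 (1.01 log units; beyond the scatter) is the only one measured so far. Compound 3 `Nc1ccc2c(c1)c(N)nn2C(=O)Nc1ccc(Cc2ccccc2)cc1` is the next member, not yet measured. It differs from compound 2 by amino in place of chloro on an aromatic carbon. Within the data shown here, the change touches the very position where the chloro brought the large drop in number seen in a 10-fold lower number from compound 1 to compound 2 (1.01 log units; beyond the scatter), but no measured step exchanges chloro for amino anywhere, so the direction of this particular swap cannot be read from a recorded pair. The one relevant observation is that compound 1, bare at this position, sits far higher than compound 2; an amino here may keep part of the gain or may not. Compound 3 is therefore expected to land between the two measured numbers, the step of a 4.9-fold higher number from compound 2 to compound 3 (0.69 log units; beyond the scatter) being the estimated outcome, with the estimate for compound 3 at 250 nM and a range from 60 nM to 1000 nM.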

Compound 3, concentration for 50% growth inhibition: 3960 nM
Estimate against measurement, compound 3: 16-fold (1.20 log units) below, and the stated range ends below it.
By their numbers in this assay, from the lowest: compound 2; then compound 1; then compound 3.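

This position turns out to work in both directions, which the earlier pair could not show. In this assay, chloro on this aromatic carbon gives a 10-fold lower number from compound 1 to compound 2 (1.01 log units; beyond the scatter), while amino at the same carbon gives a 7.5-fold higher number from compound 1 to compound 3 (0.87 log units; beyond the scatter), so compound 3 sits on the far side of the unsubstituted compound 1 from compound 2, and a substituent here does not in itself lower the number. Among these compounds, exchanging the two groups directly gives a 77-fold higher number from compound 2 to compound 3 (1.89 log units; beyond the scatter), a larger step than either step from compound 1, and this single-atom change, which brings in a hydrogen-bond donor and acceptor that chloro lacks, is the largest difference so far; nothing available accounts for why these two groups part so widely.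

The compounds shown leave open whether fluoro or bromo on this carbon would follow chloro, and whether methyl or methoxy would fall on the side of compound 2 or of compound 3. They also leave open whether an acetamide in place of the amino would restore any of the lost ground, and whether this order holds outside this assay.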